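Trifluoromethyl to methyl on the benzimidazole-series aryl group

This account rests on a few compounds, and the source may have more. Where it says the series, first, only, none or still open, it means among the compounds named here.

Working notes on three measured compounds and one pending. In a functional assay on CHO cells for antagonist activity at transient receptor potential cation channel subfamily V member 1 (Homo sapiens), read by FLIPR (a higher number here means a weaker inhibitor, a lower number a stronger inhibitor), compound 1 `Cc1cccnc1-c1ccc(NC(=O)c2ccc(C(F)(F)F)cc2)cc1` gives 160 nM and compound 2 `Cc1cccnc1-c1ccc(NC(=O)c2cccc(C(F)(F)F)c2)cc1` gives 640 nM. Compound 3 `FC(F)(F)c1ccc(-c2nc3cc(-c4ncccc4C(F)(F)F)ccc3[nH]2)cc1` gives 22 nM in this assay, the lowest of the three numbers: compound 1 stands nearest, with a higher number beyond the scatter, and compound 2 stands furthest, also beyond the scatter. The shared core of compound 1 and compound 2 differs from that of compound 3, so no single-point comparison links them.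

Compound 4 `Cc1ccc(-c2nc3cc(-c4ncccc4C(F)(F)F)ccc3[nH]2)cc1` is not yet measured. It differs from compound 3 in one place: methyl in place of trifluoromethyl on an aromatic carbon. Going by the values given here, no measured pair in the set shows this exchange, so its effect in this assay is open. The working expectation is a weakening step from compound 3 to compound 4 of a 3.6-fold higher number from compound 3 to compound 4 (0.56 log units; beyond the scatter), modest and possibly within the scatter. Compound 4 is therefore estimated at 80 nM, with a range from 20 nM to 400 nM.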

Compound 4, half-maximal inhibitory concentration: 170 nM
Beside the measured number, compound 4's estimate is 2.1-fold (0.33 log units) below it, and the stated range covers the measured number.
By their numbers in this assay, from the lowest: compound 3; then compounds 1 and 4 (each within the scatter of the next); then compound 2.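

In this assay, going by these compounds alone, the exchange of trifluoromethyl for methyl on an aromatic carbon, para to a large group, gives a 7.7-fold higher number from compound 3 to compound 4 (0.89 log units; beyond the scatter), the first comparison in which only one place changes. This position is therefore not indifferent to the group it carries, and within this pair the lower number belongs to the trifluoromethyl compound, though a single pair sets no trend. Nothing available explains the step.

Still open, from the compounds shown here alone, is how a chlorine atom, a methoxy group or a nitrile at this place would compare with trifluoromethyl and methyl. Also open, going by these compounds, is whether the same exchange at the other trifluoromethyl group of compound 3, or on the core of compound 1, would give a step of similar size.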